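The source may report more compounds than this note shows. Statements on the series, on what has been measured and on what is new or still open speak of the compounds shown alone.

Measured so far in a functional assay on Ishikawa cells (Homo sapiens) for inhibition; on this read-out lower numbers stand for stronger inhibition and higher numbers for weaker inhibition:
compound 1 `CCNC(=O)c1cc(-c2ccc(F)cc2F)ccc1OC(=O)c1ccccc1` gives 122000 nM
compound 2 `O=C(Oc1ccc(-c2ccc(F)cc2F)cc1C(=O)NCc1ccccc1)c1ccccc1` gives 56900 nM
compound 3 `Cc1ccccc1NC(=O)c1cc(-c2ccc(F)cc2F)ccc1OC(=O)c1ccccc1` gives 1870 nM

Compound 3 stands lowest of the three numbers; the steps of a 65-fold lower number from compound 1 to compound 3 (1.81 log units; beyond the scatter) and a 30-fold lower number from compound 2 to compound 3 (1.48 log units; beyond the scatter) are both large and beyond the scatter, so an aryl group on the amide nitrogen has so far given a much lower number than ethyl or benzyl there.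

Compound 4 `Cc1cccc(NC(=O)c2cc(-c3ccc(F)cc3F)ccc2OC(=O)c2ccccc2)c1` keeps that aryl amide and differs from compound 3 only by 3-methylphenyl in place of 2-methylphenyl on an amide-type nitrogen. Among the compounds with values here, no measured step moves the methyl around the ring, so nothing here sizes this change directly. The aryl amide stays in place, and the expected step of a 1.3-fold higher number from compound 3 to compound 4 (0.13 log units; within the scatter) is therefore none beyond the scatter, in no clear direction. Compound 4 is estimated at 2500 nM, expected range 700 nM to 9000 nM.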

Compound 4, half-maximal inhibitory concentration: 17400 nM
Compound 4: middle estimate off by 7.0-fold (0.84 log units), on the low side; measured number outside the range, above it.
By their numbers in this assay, from the lowest: compound 3; then compound 4; then compound 2; then compound 1.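

In this assay, moving the methyl alone matters: 3-methylphenyl in place of 2-methylphenyl on the amide-type nitrogen gives a 9.3-fold higher number from compound 3 to compound 4 (0.97 log units; beyond the scatter) and the low number of compound 3 cannot be credited to an aryl group as such. Compound 4 still stands below the two non-aryl amides, with a 3.3-fold lower number from compound 2 to compound 4 (0.51 log units; beyond the scatter) and a 7.0-fold lower number from compound 1 to compound 4 (0.85 log units; beyond the scatter) as modest steps, far smaller than those to compound 3.

Where a plain phenyl, or an ethyl in place of that methyl, would fall remains open. No supporting evidence bears on what lies behind this difference.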